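This account rests on a few compounds, and the source may have more. Where it says the series, first, only, none or still open, it means among the compounds named here.

Measured in a toxicity assay on cells (Macrophage, Homo sapiens) for inhibition, read by MTT assay; on this read-out lower numbers stand for stronger inhibition and higher numbers for weaker inhibition:

- Compound 1 `CN1CCN(CCCNc2nc(-c3ccc(Cl)cc3)nc3ccccc23)CC1`: "nd" (no result reported)
- Compound 2 `CN(C)CCNc1nc(-c2ccc(Cl)cc2)nc2ccccc12`: 60000 nM
- Compound 3 `NCCNc1nc(-c2ccc(Cl)cc2)nc2ccccc12`: 15000 nM

Compound 2 holds the higher of the two numbers available, and compound 1 offers no number for comparison. Among the measured compounds shown here, the one measured step, a 4.0-fold lower number from compound 2 to compound 3 (0.60 log units; beyond the scatter), is modest and replaces dimethylamino with amino on a saturated chain carbon.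

Compound 4 `CN(C)CCNc1nc(-c2ccc(O)cc2)nc2ccccc12` keeps that chain of compound 2 and differs elsewhere: hydroxy in place of chloro on an aromatic carbon. This puts hydroxy in place of chloro on an aromatic carbon, para to a large group. For the measured compounds named here, no measured step touches this place, so the data show neither the size nor the direction of this change directly. Going by the values given here, the chain step remains the only guide to scale, and it bears on the question only loosely. In this assay, a step no larger than that one is expected, probably within the scatter, with a slight lean towards a lower number. The estimated step is a 1.5-fold lower number from compound 2 to compound 4 (0.18 log units; within the scatter). For compound 4 the estimate is 40000 nM, with an expected range from 15000 nM to 100000 nM.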

Compound 4, half-maximal inhibitory concentration: 51000 nM
Beside the measured number, compound 4's estimate is 1.3-fold (0.11 log units) below it; the measured number falls inside the stated range.
By their numbers in this assay, from the lowest: compound 3; then compounds 4 and 2 (each within the scatter of the next).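

Replacing chloro with hydroxy on the aromatic carbon para to a large group, the 4-chlorophenyl to 4-hydroxyphenyl change, gives a 1.2-fold lower number from compound 2 to compound 4 (0.07 log units; within the scatter) in this assay, so this assay does not separate compound 2 from compound 4. The earlier compounds shown here showed only a change on the chain, a 4.0-fold lower number from compound 2 to compound 3 (0.60 log units; beyond the scatter), and this first change on the aromatic ring shows that adding one hydrogen-bond donor and one hydrogen-bond acceptor here need not produce a step beyond the scatter. The data offer no measured explanation for this outcome.

From the compounds shown here alone, whether a different group at this position, such as methoxy, an amine or a carboxylic acid, would give a step beyond the scatter remains open. Going by these compounds, it is also open whether hydroxy in place of chloro would give the same outcome when paired with the amino chain of compound 3.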